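A few compounds are considered here, and "the series" means these few. Any claim that something is new, unique, unknown or untested is made for them only; others in the source may bear on it.

Compound 1 `O=C(O)C1CCN(c2ccccc2Cl)C1` gives 19000 nM in an assay on cells for inhibition of Palmitoleoyl-protein carboxylesterase NOTUM variant C330S (Homo sapiens), read by fluorescence, with a stated time of 40 min; a higher number here means a weaker inhibitor, a lower number a stronger inhibitor. Compound 2 `O=C(O)C1CCN(c2cccc(OC(F)(F)F)c2)C1` gives 63000 nM in this assay. Compound 3 `O=C(O)C1CCN(c2ccc(Cl)cc2Cl)C1` gives 10000 nM in this assay.

Of the three numbers compound 3 has the lowest, but compound 1 sits within the scatter of it; only compound 2 lies beyond the scatter. Compound 4 `O=C(O)C1CCN(c2ccc(Cl)c(Cl)c2Cl)C1` differs from compound 3 by chloro in place of hydrogen on an aromatic carbon. Among the compounds with values here, one measured step bears on this change, the same kind of addition of a chloro group, and it was a 1.9-fold lower number from compound 1 to compound 3 (0.28 log units; within the scatter), within the scatter. On that basis the expected step is a 1.4-fold lower number from compound 3 to compound 4 (0.15 log units; within the scatter), a change no larger than the scatter, if anything toward a lower number. Compound 4 is therefore estimated at 7000 nM, with a range from 3000 nM to 20000 nM.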

Compound 4, half-maximal inhibitory concentration: 600 nM
Beside the measured number, compound 4's estimate is 12-fold (1.07 log units) above it; the measured number lies below the stated range.
By their numbers in this assay, from the lowest: compound 4; then compounds 3 and 1 (each within the scatter of the next); then compound 2.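

In this assay, adding a chloro group gave a 17-fold lower number from compound 3 to compound 4 (1.22 log units; beyond the scatter), whereas the earlier addition of a chloro group gave a 1.9-fold lower number from compound 1 to compound 3 (0.28 log units; within the scatter). The same change therefore does not carry one size of step across these compounds, and at this place, ortho to two chloro groups, the step is large. Nothing available here accounts for the size of this step.

On these data alone, it remains open whether a bromo or methyl group at this place would give a similar step. As far as these compounds go, it is also open whether an amide in place of the carboxylic acid would keep the lower number of compound 4.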